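Swapping a Ring Amine for an Open-Chain Amine

A few compounds are considered here, and "the series" means these few. Any claim that something is new, unique, unknown or untested is made for them only; others in the source may bear on it.

Measured compounds in an ADME assay on 184B5 cells (Homo sapiens) for cytotoxicity, read by sulforhodamine B assay, with a stated time of 48 h; on this read-out lower numbers stand for stronger inhibition of growth and higher numbers for weaker inhibition of growth:
Compound 1 `Cc1ccc2nc(/N=C3\C(=O)N(CN4CCCCC4)c4ccccc43)sc2c1`: 34900 nM
Compound 2 `CN(C)CN1C(=O)C(=O)c2c(Br)cccc21`: 77900 nM
Compound 3 `O=C1C(=O)N(CN2CCCCC2)c2cccc(Br)c21`: 85200 nM

Compound 3 has the highest number of the three in this assay, meaning the weakest inhibition of growth. Its nearest neighbour is compound 2, whose number lies within the usual scatter of compound 3, so no order can be read between them. Compound 1 is further away, with a number beyond the scatter below that of compound 3.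

Going by the values given here, the one step that bears on the question is the change from compound 2 to compound 3, where the amine on the saturated chain carbon was exchanged: a 1.1-fold higher number from compound 2 to compound 3 (0.04 log units; within the scatter). That exchange of one amine for another left the number essentially where it was.

Compound 4 `CCN(CC)CN1C(=O)C(=O)c2c(Br)cccc21` differs from compound 3 in the same region: diethylamino in place of piperidin-1-yl on a saturated chain carbon bound to an amide-type nitrogen in a ring. Because the comparable amine swap gave a 1.1-fold higher number from compound 2 to compound 3 (0.04 log units; within the scatter), a similarly small shift is expected here, with no change beyond the scatter in this assay: a 1.1-fold lower number from compound 3 to compound 4 (0.03 log units; within the scatter). Compound 4 is therefore estimated at 80000 nM, with a range from 40000 nM to 160000 nM.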

Compound 4, concentration for 50% growth inhibition: 172000 nM
Estimate against measurement, compound 4: 2.2-fold (0.33 log units) below; the whole stated range lies below it.
By their numbers in this assay, from the lowest: compound 1; then compounds 2 and 3 (each within the scatter of the next); then compound 4.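

With diethylamino on the saturated chain carbon bound to an amide-type nitrogen in a ring, this assay shows weaker inhibition of growth, with a 2.0-fold higher number from compound 3 to compound 4 (0.31 log units; beyond the scatter) and a 2.2-fold higher number from compound 2 to compound 4 (0.34 log units; beyond the scatter) both beyond the scatter, so this position does not accept every amine equally. Ring versus open chain does not sort these three amines: open-chain dimethylamino stays within the scatter of ring piperidin-1-yl, while open-chain diethylamino parts from both. Nothing shown here gives a reason for this shift.

Still open, from the compounds shown here alone, is whether a longer chain on the nitrogen, such as dipropylamino, would raise the number further, or whether a ring amine such as morpholin-4-yl would stay with piperidin-1-yl. Also open, going by these compounds, is whether diethylamino would act the same way on the core of compound 1.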